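An Acylated Aniline on the Thiophene-Bearing Core

The compounds below may be only part of what the source reports. "The series", "measured", "known", "first", "only" and "open" are said of these compounds alone.

Compound 1 `Nc1cccc(-c2cn3nc(-c4cccs4)sc3n2)c1` carries a free amino group on a phenyl ring attached to the shared core. In a functional assay on L1210 cells (Mus musculus) for inhibition, read by cell counting, with a stated time of 2 days (on this read-out higher numbers stand for weaker inhibition and lower numbers for stronger inhibition), compound 1 reaches only > 250000 nM, which is a limit of the measurement and not a number. This rests on (the limit of > 250000 nM in this assay, at which 1 of the 2 values shown sits), so compound 1 stands at the weak end of everything shown here. For the measured compounds named here, compound 2 `Nc1cccc(-c2cn3nc(CCc4ccccc4)sc3n2)c1`, in which a 2-phenylethyl chain takes the place of the thiophene on the core, is the only other measured compound: in this assay compound 2 gives 31000 nM, a measurable number where compound 1 gave none.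

Compound 3 `C=C(Br)C(=O)Nc1cccc(-c2cn3nc(-c4cccs4)sc3n2)c1` differs from compound 1 in one place: (1-bromoethenyl)carbonyl in place of hydrogen on a nitrogen on an aromatic ring. Since compound 1 sits at the limit, any number read for compound 3 would mean stronger inhibition, and a stronger result is what is expected here. The step from compound 1 to compound 3 is expected at an at least 12-fold lower number from compound 1 to compound 3 (1.09 log units; beyond the scatter), toward stronger inhibition and beyond the usual scatter. Compound 3 is estimated at 20000 nM, with a likely range from 3000 nM to 200000 nM.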

Compound 3, half-maximal inhibitory concentration: 170 nM
The estimate for compound 3 lay 120-fold (2.07 log units) above the measured number; measured number below the stated range.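

Compounds 1 and 2 both carry a free amino group, so they said nothing about what happens when that nitrogen is substituted. Compound 3 supplies that test: in this assay, (1-bromoethenyl)carbonyl in place of hydrogen on a nitrogen on an aromatic ring gives an at least 1400-fold lower number from compound 1 to compound 3 (3.16 log units; beyond the scatter). This single change thus turns a compound with no measurable number into one with a clear one, and the printed size of the step is a minimum, not an exact figure, since compound 1 has only a limit and not a number: the limit of > 250000 nM in this assay, at which 1 of the 3 values shown sits.

The compounds shown do not tell which part of the entering group matters, and an acetyl group or a propenoyl group without the bromine on the same nitrogen would help separate the carbonyl from the double bond and the bromine. Also open, going by these compounds, is whether (1-bromoethenyl)carbonyl on the amino group of compound 2, with its 2-phenylethyl chain in place of the thiophene, would bring a step of similar size.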